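The source may hold more compounds than are shown below. What is called first, only, known or untested is meant among the compounds shown, and "the series" means these compounds.

Measured compounds in a functional assay on CCRF-CEM cells (Homo sapiens) for inhibition, read by cell counting, with a stated time of 3 days; a higher number here means a weaker inhibitor, a lower number a stronger inhibitor: compound 1 `COc1ccc(-c2nn3cc(-c4cccc(N)c4)nc3s2)cc1OC` gives 14000 nM; compound 2 `Nc1cccc(-c2cn3c(-c4ccccc4)csc3n2)c1` gives 29000 nM. Compound 3 `COc1ccc(-c2nn3cc(-c4cccc(N)c4)nc3s2)cc1` gives only a limit in this assay, >= 250000 nM, and that is a limit rather than a number; one of the three values sits at the limit of >= 250000 nM in this assay, at which 1 of the 3 values shown sits.

Compound 3 and compound 1 share a core and differ by methoxy in place of hydrogen on an aromatic carbon. This change gave an at least 17-fold lower number from compound 3 to compound 1 (1.25 log units; beyond the scatter). Compound 2 has a different core from compound 3, and the difference between the two cores is not broken down here. Compound 4 `COc1ccc(-c2csc3nc(-c4cccc(N)c4)cn23)cc1`, not yet measured, differs from compound 2 by methoxy in place of hydrogen on an aromatic carbon. This is the same kind of change as that from compound 3 to compound 1, but not the same: the entering methoxy in compound 4 sits para to a large group, whereas in compound 1 it sits ortho to a methoxy group and meta to a large group. The large step from compound 3 to compound 1 rests on a single pair on another core, so for compound 4 a smaller step is expected, a 1.0-fold higher number from compound 2 to compound 4 (0.01 log units; within the scatter). Compound 4 is estimated at 30000 nM in this assay, expected between 8000 nM and 150000 nM.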

Compound 4, half-maximal inhibitory concentration: 6100 nM
Compound 4: middle estimate off by 4.9-fold (0.69 log units), on the high side, outside the stated range (below it).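

In this assay, methoxy in place of hydrogen on an aromatic carbon also lowered the number on the core of compound 2, giving a 4.8-fold lower number from compound 2 to compound 4 (0.68 log units; beyond the scatter), so the direction of the earlier step on the other core carried over in this one further pair. Going by these compounds alone, the size did not carry over, and with only two pairs, in which the methoxy enters at different places on the ring, the compounds do not separate the effect of the core from that of the position: the same change on two cores in this assay, an at least 17-fold lower number (1.25 log units; beyond the scatter) from compound 3 to compound 1 and a 4.8-fold lower number (0.68 log units; beyond the scatter) from compound 2 to compound 4, at least 3.7-fold (0.57 log units) apart, beyond the scatter of two such steps Compound 3 gives >= 250000 nM, which is a limit and not a number.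

The compounds shown leave open whether a different group at the same place, such as a chlorine, a hydroxyl or an ethoxy, would lower the number on both cores as methoxy does. They also leave open how the step would behave if the amine on the other benzene ring were replaced by a hydroxyl or an amide.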